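The source may report more compounds than this note shows. Statements on the series, on what has been measured and on what is new or still open speak of the compounds shown alone.

Compound 1 `Cc1cccc(NC(=S)N/N=C/c2ccc3ccccc3n2)c1` is one of two thiosemicarbazones measured here. In a functional assay on HL-60 cells (Homo sapiens) for antiproliferative activity, read by sulforhodamine B assay, with a stated time of 72 h (on this read-out lower numbers stand for stronger inhibition and higher numbers for weaker inhibition), compound 1 gives only a limit of the assay, > 100000 nM, and not a number. This is recorded as the limit of > 100000 nM in this assay, at which 1 of the 2 values shown sits, so compound 1 stands at the weak edge of what the assay can report. Within the data shown here, the other measured compound, compound 2 `CC(C)c1cccc(C(C)C)c1NC(=S)N/N=C/c1ccc2ccccc2n1`, gives 19500 nM in this assay; the two compounds differ in more than one place, so no single step between them can be read.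

Compound 3 `Fc1ccc(NC(=S)N/N=C/c2ccc3ccccc3n2)cc1` is not yet measured. It differs from compound 1 by 4-fluorophenyl in place of 3-methylphenyl on an amide-type nitrogen. Among the measured compounds shown here, with no measured step of this kind to draw on, the change from compound 1 to compound 3 is expected to be small, likely none beyond the scatter, although compound 3 could fall just inside the measurable range. Compound 3 is therefore estimated at 60000 nM in this assay, with a range from 15000 nM to 250000 nM, which means an expected step of an at least 1.6-fold lower number from compound 1 to compound 3 (0.22 log units; that floor lies within the scatter).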

Compound 3, half-maximal inhibitory concentration: 17000 nM
The estimate for compound 3 lay 3.5-fold (0.55 log units) above the measured number; measured number inside the range.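

On the amide-type nitrogen whose other neighbour is the thiocarbonyl carbon, the choice of aryl group proves to matter: in this assay, 4-fluorophenyl in place of 3-methylphenyl gives an at least 5.8-fold lower number from compound 1 to compound 3 (0.76 log units; beyond the scatter). Among these compounds, this is the first single change that can be read at this position, and it brings the shared core from the limit of this assay into the measurable range. The step is a bound and not a full size, since compound 1 gives a limit and not a number: the limit of > 100000 nM in this assay, at which 1 of the 3 values shown sits.

The compounds shown cannot separate the contribution of the fluorine from that of the lost methyl, and the steps to compound 2 cannot be read. They also leave open how a plain phenyl, a 4-chlorophenyl or a 4-methoxyphenyl would fare on this nitrogen.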